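Alkynyl substituent swap on the diol series

The source may hold more compounds than are shown below. What is called first, only, known or untested is meant among the compounds shown, and "the series" means these compounds.

Compound 3 `O=c1[nH]c(=O)n(CCC(CO)CO)cc1C#Cc1cc(F)cc(F)c1` is the free diol of the series, and in a functional assay on MCF7 cells (Homo sapiens) for antiproliferative activity, read by MTT assay, with a stated time of 72 h (a higher number here means a weaker inhibitor, a lower number a stronger inhibitor), compound 3 gives 63100 nM. For the measured compounds named here, this is the highest of the three numbers measured so far. The nearest number belongs to compound 1 `CC(=O)OCC(CCn1cc(C#Cc2cc(F)cc(F)c2)c(=O)n(C(=O)c2ccccc2)c1=O)COC(C)=O`, which in this assay gives 28900 nM, a gap beyond the scatter; the furthest belongs to compound 2 `CC(=O)OCC(CCn1cc(C#CC2CC2)c(=O)n(C(=O)c2ccccc2)c1=O)COC(C)=O`, which gives 100 nM.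

Compound 4 `CCCCCC#Cc1cn(CCC(CO)CO)c(=O)[nH]c1=O` differs from compound 3 in one place: pentyl in place of 3,5-difluorophenyl on a triple-bonded carbon. Going by the values given here, the only measured step that bears on this is the one from the diacetate pair, where cyclopropyl took the place of 3,5-difluorophenyl on the same triple-bonded carbon and the number dropped by a 290-fold lower number from compound 1 to compound 2 (2.46 log units; beyond the scatter). Among the compounds with values here, that step replaced the same leaving group, though with a different small entering group and on a different version of the core; no measured step shows pentyl itself, and none shows the diol core with a non-aromatic alkyne substituent.

On that basis a large drop is expected for compound 4, estimated as a 32-fold lower number from compound 3 to compound 4 (1.50 log units; beyond the scatter). Compound 4 is therefore expected to give about 2000 nM in this assay, within a range of 300 nM to 15000 nM.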

Compound 4, half-maximal inhibitory concentration: 37800 nM
For compound 4 the middle estimate is 19-fold (1.28 log units) below the measured one, outside the stated range (above it).
By their numbers in this assay, from the lowest: compound 2; then compounds 1, 4 and 3 (each within the scatter of the next, the first and the last beyond it).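

In this assay the swap on the free diol gives a 1.7-fold lower number from compound 3 to compound 4 (0.22 log units; within the scatter) and so leaves the number within the scatter: on this triple-bonded carbon, pentyl stands in for 3,5-difluorophenyl with no readable change. Removing the aromatic ring from this carbon is therefore not enough on its own to produce a large step, even though the ring also leaves in the diacetate pair, where the result is a 290-fold lower number from compound 1 to compound 2 (2.46 log units; beyond the scatter) and lies well beyond the scatter. The two steps differ in both the entering group and the core, so the large step of the diacetate pair cannot be treated as a general effect of replacing 3,5-difluorophenyl at this carbon.

No supporting measurement accounts for the contrast between these two steps. From the compounds shown here alone, it remains open whether the deciding factor is cyclopropyl itself or the core of compound 2, which could be separated by placing cyclopropyl on the free diol and pentyl on the diacetate, while a longer chain or an amine on the same triple-bonded carbon would test how far this tolerance extends.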